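Isopropoxy in place of tert-butyl on the pendant ring

The source may report more compounds than this note shows. Statements on the series, on what has been measured and on what is new or still open speak of the compounds shown alone.

Measured in a functional assay on HepG2 cells (Homo sapiens) for antiproliferative activity, read by MTT assay, with a stated time of 48 h; on this read-out lower numbers stand for stronger inhibition and higher numbers for weaker inhibition:
compound 1 `C=CCN1C(=O)C(=O)c2cc(-c3ccc(OC)cc3)ccc21`, 7090 nM
compound 2 `COc1ccc(CN2C(=O)C(=O)c3cc(-c4cccc(OC)c4)ccc32)cc1`, 1890 nM
compound 3 `COc1ccc(CN2C(=O)C(=O)c3cc(-c4ccc(C(C)(C)C)cc4)ccc32)cc1`, 4580 nM
Not yet measured: compound 4 `COc1ccc(CN2C(=O)C(=O)c3cc(-c4ccc(OC(C)C)cc4)ccc32)cc1`.

Compound 3 sits second highest of the three numbers in this assay. Compound 1 stands nearest to it, within the scatter, so no order between compound 3 and compound 1 can be read. Compound 2 lies clearly below: the step of a 2.4-fold higher number from compound 2 to compound 3 (0.38 log units; beyond the scatter), which exchanged the whole pendant ring, is modest but beyond the scatter.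

The change now in hand is isopropoxy in place of tert-butyl on an aromatic carbon. Among the measured compounds shown here, only one measured step touches the same position of the molecule, a 2.4-fold higher number from compound 2 to compound 3 (0.38 log units; beyond the scatter), and it changed both the substituent and its place on the ring; the step to compound 4 keeps the place and swaps one group of four heavy atoms for another, adding one acceptor. For the measured compounds named here, no measured pair isolates that swap. Given that the larger ring exchange moved the number only modestly, the step for compound 4 is expected to stay small, with a slight lean toward a lower number, roughly a 1.3-fold lower number from compound 3 to compound 4 (0.12 log units; within the scatter). Compound 4 is therefore estimated at 3500 nM, within 1500 nM to 8000 nM.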

Compound 4, half-maximal inhibitory concentration: > 10000 nM
Compound 4 was reported as a limit (the forecaster's own chance of this, stated with the estimate: 5%); at least 2.8-fold (0.45 log units) between middle value and limit.
By their numbers in this assay, from the lowest: compound 2; then compounds 3 and 1 (each within the scatter of the next). At a limit, above all of these: compound 4.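

In this assay compound 4 stands at > 10000 nM, a limit of the assay and not a number, and it is the only compound shown that sits at this limit: the limit of > 10000 nM in this assay, at which 1 of the 4 values shown sits. At the place para to a large group, then, swapping tert-butyl for isopropoxy is not a neutral exchange, even though the heavy-atom count stays the same and only one hydrogen-bond acceptor enters: an at least 2.1-fold higher number from compound 3 to compound 4 (0.33 log units; beyond the scatter). Measured from compound 2, the 4-isopropoxyphenyl exchange gives an at least 5.2-fold higher number from compound 2 to compound 4 (0.72 log units; beyond the scatter), whereas the earlier exchange to 4-(tert-butyl)phenyl gave only a 2.4-fold higher number from compound 2 to compound 3 (0.38 log units; beyond the scatter), and compound 2 itself, whose 3-methoxyphenyl also carries an oxygen on the pendant ring, goes against any reading that a ring-bound oxygen alone raises the number.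

Still open, from the compounds shown here alone, is how far beyond the limit compound 4 lies, and whether the shift follows the oxygen, its place on the ring or the branching of the isopropyl part. Going by these compounds, how an amine, a carboxylic acid or a longer straight alkoxy chain would read at this place also remains open.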